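Furan-2-yl Carbonyl in Place of Acetyl on a Triterpenoid Core

The source may report more compounds than this note shows. Statements on the series, on what has been measured and on what is new or still open speak of the compounds shown alone.

Going by the values given here, compound 1 `CC(=O)O[C@H]1CC[C@]2(C)[C@H](CC[C@@](C)(O)[C@H]2CC[C@@H]2C(C)=CC[C@H]3[C@H](CC[C@]3(C)O)C2(C)C)OC1(C)C` carries the highest of the two numbers measured so far, though its only neighbour sits within the scatter. In a functional assay on MDA-MB-231 cells (Homo sapiens) for antiproliferative activity, read by MTT assay, with a stated time of 72 h (on this read-out higher numbers stand for weaker inhibition and lower numbers for stronger inhibition), compound 1 gives 38000 nM. Compound 2 `CC1=CC[C@H]2[C@H](CC[C@]2(C)O)C(C)(C)[C@@H]1CC[C@H]1[C@]2(C)CC[C@H](OC(=O)c3ccccc3C(F)(F)F)C(C)(C)O[C@H]2CC[C@@]1(C)O`, which carries a 2-(trifluoromethyl)phenyl in place of methyl on a carbonyl carbon, gives 31500 nM in this assay; the step of a 1.2-fold lower number from compound 1 to compound 2 (0.08 log units; within the scatter) is the only one measured.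

Compound 3 `CC1=CC[C@H]2[C@H](CC[C@]2(C)O)C(C)(C)[C@@H]1CC[C@H]1[C@]2(C)CC[C@H](OC(=O)c3ccco3)C(C)(C)O[C@H]2CC[C@@]1(C)O` differs from compound 1 by furan-2-yl in place of methyl on a carbonyl carbon. The step from compound 1 to compound 2 bears directly on this change, since it also exchanges the methyl on the same carbonyl carbon for an aromatic ring and moved the number only within the scatter. Compound 3 is therefore expected to show no step beyond the scatter, a 1.2-fold lower number from compound 1 to compound 3 (0.06 log units; within the scatter). Compound 3 is estimated at 33000 nM in this assay, with a range from 14000 nM to 75000 nM.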

Compound 3, half-maximal inhibitory concentration: 14000 nM
Compound 3: the middle estimate sits 2.4-fold (0.37 log units) above what was measured; measured number inside the range.
By their numbers in this assay, from the lowest: compound 3; then compounds 2 and 1 (each within the scatter of the next).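

In this assay, going by these compounds alone, the carbonyl carbon of this ester proves responsive to the group it carries: furan-2-yl in place of methyl gives the first step here beyond the scatter (a 2.7-fold lower number from compound 1 to compound 3 (0.43 log units; beyond the scatter)). The identity of the ring also counts, since furan-2-yl in place of 2-(trifluoromethyl)phenyl gives a step of similar size (a 2.3-fold lower number from compound 2 to compound 3 (0.35 log units; beyond the scatter)), so an aromatic ring on this carbon does not by itself set the number. Nothing at hand accounts for the modest difference furan-2-yl makes.

The compounds shown leave open whether a thiophen-2-yl or an unsubstituted phenyl on this carbonyl carbon would match furan-2-yl. They also leave open how a saturated ring such as tetrahydrofuran-2-yl, or a chain bearing an amine, would read at this place.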